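Arylamine to cyclopentylamine on a shared quinone core

The source may report more compounds than this note shows. Statements on the series, on what has been measured and on what is new or still open speak of the compounds shown alone.

Measured so far in a functional assay on ECa-109 cells for inhibition, with ECa-109 cell line (Homo sapiens) as the target, read by sulforhodamine B assay; a lower number here means a stronger inhibitor, a higher number a weaker inhibitor:
compound 1 `O=C1C=C(Nc2ccc(I)cc2)C(=O)c2c1nc1n2[C@H]2OC[C@@H](O)[C@H]2OC1` gives 2300 nM
compound 2 `COc1cccc(NC2=CC(=O)c3nc4n(c3C2=O)[C@H]2OC[C@@H](O)[C@H]2OC4)c1` gives 7620 nM
compound 3 `O=C1C=C(Nc2cccc(Cl)c2)C(=O)c2c1nc1n2[C@H]2OC[C@@H](O)[C@H]2OC1` gives 4690 nM

Compound 3 stands second highest of the three numbers. Its nearest neighbour is compound 2, where the difference a 1.6-fold lower number from compound 2 to compound 3 (0.21 log units; within the scatter) stays within the scatter; the step of a 2.0-fold higher number from compound 1 to compound 3 (0.31 log units; beyond the scatter) lies beyond it, so compound 1 is the stronger inhibitor of that pair. Going by the values given here, the only other measured step, a 3.3-fold higher number from compound 1 to compound 2 (0.52 log units; beyond the scatter), is also modest.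

Compound 4 `O=C1C=C(NC2CCCC2)C(=O)c2c1nc1n2[C@H]2OC[C@@H](O)[C@H]2OC1` differs from compound 3 by cyclopentyl in place of 3-chlorophenyl on an amine nitrogen. All three measured steps concern exchanges of one substituted phenyl for another on the amine nitrogen; none replaces the aromatic ring by a non-aromatic one, so they bear on this step only loosely, by showing that changes at this position have so far moved this assay by modest amounts. Because the aryl-to-aryl steps a 3.3-fold higher number from compound 1 to compound 2 (0.52 log units; beyond the scatter) and a 2.0-fold higher number from compound 1 to compound 3 (0.31 log units; beyond the scatter) were both modest, and the present change removes the aromatic ring entirely, a somewhat larger weakening is expected, with wide uncertainty. The step of a 1.9-fold higher number from compound 3 to compound 4 (0.28 log units; within the scatter) is the estimate. Compound 4 is therefore expected to give about 9000 nM, within a range from 3000 nM to 27000 nM.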

Compound 4, half-maximal inhibitory concentration: > 16000 nM
Compound 4 was reported as a limit; the forecaster's own chance of this, stated with the estimate: 15%; middle value at least 1.7-fold (0.24 log units) away from the limit.
By their numbers in this assay, from the lowest: compound 1; then compounds 3 and 2 (each within the scatter of the next). At a limit, above all of these: compound 4.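

The value of compound 4 in this assay is a limit and not a number: the limit of > 16000 nM in this assay, at which 1 of the 4 values shown sits. Even so, the exchange of an aromatic ring for a non-aromatic one on the amine nitrogen can be read against all three arylamines, and each step lies beyond the scatter: an at least 3.4-fold higher number from compound 3 to compound 4 (0.53 log units; beyond the scatter), an at least 2.0-fold higher number from compound 2 to compound 4 (0.32 log units; beyond the scatter) and an at least 6.9-fold higher number from compound 1 to compound 4 (0.84 log units; beyond the scatter). The earlier compounds varied only the substituted phenyl group and gave modest steps such as a 3.3-fold higher number from compound 1 to compound 2 (0.52 log units; beyond the scatter), whereas these new steps show that all three compounds with a substituted phenyl group on this nitrogen are stronger inhibitors than the one compound with cyclopentyl, and none of the compounds shown goes against this.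

Going by these compounds, a single non-aromatic example cannot separate the loss of the aromatic ring from the change of ring size, so it remains open whether cyclohexyl, or an unsubstituted phenyl, would fall with the arylamines or with compound 4. On these data alone, it is equally open how an open-chain alkyl amine or a phenyl group carrying a carboxylic acid would behave at this position, and how far the true value of compound 4 lies from its limit.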